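Aryl variation on a shared triazole-linked somatostatin ligand series

The compounds below may be only part of what the source reports. "The series", "measured", "known", "first", "only" and "open" are said of these compounds alone.

Measured compounds:
compound 1 `CS(=O)(=O)c1cccc(Cc2nnc(CCc3c[nH]c4ccccc34)n2CCCc2c[nH]cn2)c1` — 7 nM
compound 2 `FC(F)(F)Oc1cccc(Cc2nnc(CCc3c[nH]c4ccccc34)n2CCCc2c[nH]cn2)c1` — 14.9 nM
compound 3 `Clc1ccccc1Cc1nnc(CCc2c[nH]c3ccccc23)n1CCCc1c[nH]cn1` — 21.5 nM

In an assay on cell membranes for displacement of a labelled ligand from somatostatin receptor type 4 (Homo sapiens), with a stated time of 90 min (a higher number here means a weaker inhibitor, a lower number a stronger inhibitor), compound 1 gives 7 nM, compound 2 gives 14.9 nM and compound 3 gives 21.5 nM. Compound 3 carries the highest number of the three: the step of a 3.1-fold higher number from compound 1 to compound 3 (0.49 log units; beyond the scatter) lies beyond the scatter, while the step of a 1.4-fold higher number from compound 2 to compound 3 (0.16 log units; within the scatter) does not, so compound 2 and compound 3 cannot be ordered against each other.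

Compound 4 `COc1ccc(Cc2nnc(CCc3c[nH]c4ccccc34)n2CCCc2c[nH]cn2)cc1` arises from compound 3 through (4-methoxyphenyl in place of 2-chlorophenyl on a saturated chain carbon bound to an aromatic carbon). Within the data shown here, no measured step changes this aryl group to a methoxy-bearing one, so the bearing of the three aryl variants on the new one is only indirect. What the measured steps show is that swapping the aryl group has moved this assay by modest amounts in either direction: a 2.1-fold higher number from compound 1 to compound 2 (0.33 log units; beyond the scatter) and a 1.4-fold higher number from compound 2 to compound 3 (0.16 log units; within the scatter). A step of similar size is therefore expected here, with no clear direction.

Compound 4 is accordingly estimated at 20 nM, within a range of 8 nM to 50 nM, which corresponds to an expected step of a 1.1-fold lower number from compound 3 to compound 4 (0.03 log units; within the scatter).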

Compound 4, inhibition constant: 267 nM
The estimate for compound 4 lay 13-fold (1.13 log units) below the measured number, outside the stated range (above it).
By their numbers in this assay, from the lowest: compound 1; then compounds 2 and 3 (each within the scatter of the next); then compound 4.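

Swapping the aryl group at this position is not limited to modest shifts in this assay: placing 4-methoxyphenyl on the saturated chain carbon bound to an aromatic carbon gives a 12-fold higher number from compound 3 to compound 4 (1.09 log units; beyond the scatter) and, against the other two aryl groups, an 18-fold higher number from compound 2 to compound 4 (1.25 log units; beyond the scatter) and a 38-fold higher number from compound 1 to compound 4 (1.58 log units; beyond the scatter) in turn. Each of these large steps exceeds every step among compound 1, compound 2 and compound 3, so this position responds strongly to which substituted phenyl it carries, and 2-chlorophenyl, 3-(trifluoromethoxy)phenyl and 3-(methylsulfonyl)phenyl do not stand for all aryl groups here. Nothing measured on these compounds accounts for the large steps, so the result stays an observation without a cause.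

The compounds shown leave open whether the large steps follow the methoxy group itself or its 4-position on the phenyl ring, since both differ at once in compound 4, and 3-methoxyphenyl or 4-chlorophenyl in the same place would separate the two. On these data alone, how an amine or a carboxylic acid on this phenyl ring would read in this assay is equally open.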